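Bromo for acetyl at the same position

The compounds below may be only part of what the source reports. "The series", "measured", "known", "first", "only" and "open" are said of these compounds alone.

Compound 1 `c1ccc2c(-c3cn4ccnc4c(-c4ccc5ncn(C6CCCCC6)c5c4)n3)cccc2c1`: 4.32% in a functional assay on NCI-H23 cells (Homo sapiens) for inhibition, read by sulforhodamine B assay, with a stated time of 48 h, tested at 10 uM; on this read-out higher numbers stand for more inhibition at the one concentration tested (going by the name of the read-out) and lower numbers for less inhibition
Compound 2 `CC(=O)c1ccc(-c2cn3ccnc3c(-c3ccc4ncn(C5CCCCC5)c4c3)n2)cc1`: 8.6%

Compound 2 stands beside compound 1 with the two values within the scatter of each other, as the step of a number 4.3 percentage points higher from compound 1 to compound 2 (within the scatter) shows. Compound 3 `Brc1ccc(-c2cn3ccnc3c(-c3ccc4ncn(C5CCCCC5)c4c3)n2)cc1` differs from compound 2 by bromo in place of acetyl on an aromatic carbon. For the measured compounds named here, the only measured step, a number 4.3 percentage points higher from compound 1 to compound 2 (within the scatter), also alters the group at this place and stays within the scatter, so a step of about a number 0.6 percentage points lower from compound 2 to compound 3 (within the scatter) is expected for compound 3, with no change beyond the scatter. Compound 3 is therefore estimated at 8%, between 0% and 20%.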

Compound 3, a percentage reported as inhibition, at one concentration (the size of the read-out at that concentration, not a potency): 8.38%
The estimate for compound 3 lay 0.4 percentage points below the measured number, and the stated range covers the measured number.
By their numbers in this assay, from the lowest: compounds 1, 3 and 2 (each within the scatter of the next).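

In this assay, bromo in place of acetyl gives a number 0.2 percentage points lower from compound 2 to compound 3 (within the scatter), so at this place a single bromine atom and the larger acetyl, with its carbonyl, cannot be told apart. The step of a number 4.1 percentage points higher from compound 1 to compound 3 (within the scatter) shows the same for 4-bromophenyl and naphthalen-1-yl, and the three aryl groups now tested all stay within the scatter of one another. Nothing available explains this closeness. Going by these compounds, whether an amine or a carboxylic acid on this aromatic carbon would move the number beyond the scatter remains open.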